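A few compounds are considered here, and "the series" means these few. Any claim that something is new, unique, unknown or untested is made for them only; others in the source may bear on it.

Compounds with numbers in an ADME assay on CHO cells (Cricetulus griseus) for cytotoxicity; on this read-out lower numbers stand for stronger inhibition and higher numbers for weaker inhibition:
Compound 1, `C/C(=N\O)c1nc2ccccc2s1`: in this assay compound 1 gives only the limit > 100000 nM and no number.
Compound 2, `Cc1nnc(/C(=N\O)c2nc3ccccc3s2)s1`: compound 2 gives 38000 nM.
Compound 3, `Cc1cnc(/C(=N\O)c2nc3ccccc3s2)s1`: compound 3 gives 29000 nM.

Compound 3 holds the lowest of the two numbers in this assay; compound 2 is nearest, and the gap a 1.3-fold lower number from compound 2 to compound 3 (0.12 log units; within the scatter) is within the scatter, so no order between them is claimed. Compound 1 sits at the limit of > 100000 nM in this assay, at which 1 of the 3 values shown sits.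

Compound 4, `O/N=C(\c1ccccc1)c1nc2ccccc2s1`, differs from compound 3 in one place: phenyl in place of 5-methyl-1,3-thiazol-2-yl on a carbon with a double bond to nitrogen. The measured steps that touch this place are an at least 3.4-fold lower number from compound 1 to compound 3 (0.53 log units; beyond the scatter) and an at least 2.6-fold lower number from compound 1 to compound 2 (0.42 log units; beyond the scatter), both beyond the scatter when a five-membered heteroaryl replaces methyl, and a 1.3-fold lower number from compound 2 to compound 3 (0.12 log units; within the scatter), within the scatter when one such heteroaryl replaces another. Among the measured compounds shown here, no measured step exchanges a heteroaryl for phenyl, so the direction of the change is not fixed by the data. The step of a 1.4-fold higher number from compound 3 to compound 4 (0.14 log units; within the scatter) is expected to stay within the scatter, with some chance of a modestly higher number. Compound 4 is therefore estimated at 40000 nM, with a range from 15000 nM to 100000 nM in this assay.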

Compound 4, half-maximal inhibitory concentration: > 100000 nM
Compound 4: only a limit was reported; the forecaster's own chance of this, stated with the estimate: 20%; middle value at least 2.5-fold (0.39 log units) away from the limit.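

At this position, on a carbon with a double bond to nitrogen, this assay separates phenyl from the five-membered heteroaryl groups: the change gives an at least 3.4-fold higher number from compound 3 to compound 4 (0.53 log units; beyond the scatter) and an at least 2.6-fold higher number from compound 2 to compound 4 (0.42 log units; beyond the scatter), whereas exchanging one heteroaryl for the other had stayed within the scatter. Among the compounds shown, numbers now appear only with the two five-membered aromatic rings bearing hetero atoms, in compound 2 and compound 3, while the six-membered aromatic ring of carbon only in compound 4 gives no number, like methyl in compound 1, and the step between those two cannot be read. Compound 4 gives only a limit in this assay, the same limit as compound 1: the limit of > 100000 nM in this assay, at which 2 of the 4 values shown sit.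

From the compounds shown here alone, it remains open whether the hetero atoms of the ring are what tracks with the numbers, and pyridin-2-yl, or a phenyl carrying an amine or a carboxylic acid, at this place would bear on that. Also open, going by these compounds, is how a longer chain in place of methyl would read, and how compound 1 and compound 4 compare with each other.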